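This account rests on a few compounds, and the source may have more. Where it says the series, first, only, none or still open, it means among the compounds named here.

Working notes on the series. In a functional assay on HEp-2 cells (Homo sapiens) for inhibition, read by MTT assay, with a stated time of 72 h (on this read-out lower numbers stand for stronger inhibition and higher numbers for weaker inhibition), compound 1 `O=[N+]([O-])c1ccc(-c2csc(N/N=C/c3ccc(C(F)(F)F)cc3)n2)cc1` gives 27300 nM, and compound 2 `O=[N+]([O-])c1cccc(-c2csc(N/N=C/c3ccc(C(F)(F)F)cc3)n2)c1` gives 34200 nM; the step of a 1.3-fold higher number from compound 1 to compound 2 (0.10 log units; within the scatter). Compound 3 `FC(F)(F)c1ccc(/C=N/Nc2nc(-c3ccc(Cl)cc3Cl)cs2)cc1` gives 7650 nM in this assay, the lowest of the three numbers: the steps of a 3.6-fold lower number from compound 1 to compound 3 (0.55 log units; beyond the scatter) and a 4.5-fold lower number from compound 2 to compound 3 (0.65 log units; beyond the scatter) both lie beyond the scatter, so compound 3 stands apart from compound 1 and compound 2.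

Compound 4 `COc1ccc(-c2csc(N/N=C/c3ccc(C(F)(F)F)cc3)n2)cc1` is not yet measured. The change from compound 3 is 4-methoxyphenyl in place of 2,4-dichlorophenyl on an aromatic carbon. Within the data shown here, no measured step swaps the 2,4-dichlorophenyl for a group of this kind; the only steps at this place, a 3.6-fold lower number from compound 1 to compound 3 (0.55 log units; beyond the scatter) and a 4.5-fold lower number from compound 2 to compound 3 (0.65 log units; beyond the scatter), show that a nitrophenyl in place of the 2,4-dichlorophenyl gives a modestly higher number, and the exchange of 4-nitrophenyl for 3-nitrophenyl, a 1.3-fold higher number from compound 1 to compound 2 (0.10 log units; within the scatter), stays within the scatter. Among the measured compounds shown here, a 4-methoxyphenyl has no precedent here, so a modest rise in this assay back toward the numbers of compound 1 and compound 2 is expected, while a number near that of compound 3 cannot be excluded. For compound 4 the expected step is a 2.6-fold higher number from compound 3 to compound 4 (0.42 log units; beyond the scatter). Compound 4 is estimated at 20000 nM, within 6000 nM to 60000 nM.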

Compound 4, half-maximal inhibitory concentration: 11300 nM
For compound 4 the middle estimate is 1.8-fold (0.25 log units) above the measured one, and the stated range covers the measured number.
By their numbers in this assay, from the lowest: compounds 3 and 4 (each within the scatter of the next); then compounds 1 and 2 (each within the scatter of the next).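

In this assay the step of a 1.5-fold higher number from compound 3 to compound 4 (0.17 log units; within the scatter) shows that at this place, on an aromatic carbon next to the ring nitrogen, a low number does not depend on chlorine, since 4-methoxyphenyl and 2,4-dichlorophenyl cannot be told apart here. Against the nitrophenyl compounds the picture is different, with a 3.0-fold lower number from compound 2 to compound 4 (0.48 log units; beyond the scatter) and a 2.4-fold lower number from compound 1 to compound 4 (0.38 log units; beyond the scatter) both beyond the scatter, so the higher numbers in this set belong to the two nitro compounds alone. No measurement on hand bears on why these groups sort this way.

Open, as far as these compounds go, is whether an unsubstituted phenyl, a 4-chlorophenyl or a 4-aminophenyl at this place would sit with compound 3 and compound 4 or with compound 1 and compound 2. Also open, from the compounds shown here alone, is whether a carboxylic acid on this phenyl, or a longer alkoxy chain in place of methoxy, would keep the number of compound 4.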